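A few compounds are considered here, and "the series" means these few. Any claim that something is new, unique, unknown or untested is made for them only; others in the source may bear on it.

Compound 1 `CC(C)CCn1nc(-c2ccccc2)c(O)c(C2=NS(=O)(=O)c3cc(NS(C)(=O)=O)ccc3N2)c1=O`: > 1000 nM, a limit
Compound 2 `C/C(=C\c1nn(CCC(C)C)c(=O)c(C2=NS(=O)(=O)c3cc(NS(C)(=O)=O)ccc3N2)c1O)C(F)(F)F`: > 33000 nM, a limit

In an ADME assay on Huh-7 cells (Homo sapiens) for cytotoxicity, with a stated time of 72 h (a higher number here means that more compound is tolerated, a lower number that less compound is tolerated), compound 2 stands at > 33000 nM, which is a limit and not a number. Compound 3 `CC(C)CCn1nc(CCC(F)(F)F)c(O)c(C2=NS(=O)(=O)c3cc(NS(C)(=O)=O)ccc3N2)c1=O` differs from it by 3,3,3-trifluoropropyl in place of 2-(trifluoromethyl)prop-1-en-1-yl on an aromatic carbon, with 3,3,3-trifluoropropyl in place of 2-(trifluoromethyl)prop-1-en-1-yl on an aromatic carbon. Within the data shown here, the one measured step at this place is a step that the two limits leave unreadable from compound 1 to compound 2, so it gives no size to carry over. No step beyond the usual scatter is therefore expected, and no direction can be stated. The expected change is a number no higher from compound 2 to compound 3 (the limit leaves the size open). Compound 3 is estimated at 33000 nM, with an expected range of 10000 nM to 100000 nM.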

Compound 3, half-maximal cytotoxic concentration: > 33000 nM
Compound 3 gave a limit, no number (the forecaster's own chance of this, stated with the estimate: 75%); the middle value sits exactly at the limit.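

In this assay compound 3 gives > 33000 nM, a limit and not a number, and the steps among compound 1, compound 2 and compound 3 cannot be read. Going by these compounds, whether phenyl, 2-(trifluoromethyl)prop-1-en-1-yl and 3,3,3-trifluoropropyl differ at all in half-maximal cytotoxic concentration stays open.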